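Cytotoxicity notes on a quinone series, compound 4 pending

The source may hold more compounds than are shown below. What is called first, only, known or untested is meant among the compounds shown, and "the series" means these compounds.

Measured so far:
compound 1 `CC1=CCC[C@H]2[C@](C)(CC3=CC(=O)C=C(NCCC(=O)O)C3=O)[C@@H](C)CC[C@]12C` gives 80800 nM
compound 2 `CSCC[C@H](NC1=CC(=O)C=C(C(C)(C)C)C1=O)C(=O)O` gives > 200000 nM
compound 3 `CC(C)(C)C1=CC(=O)C=CC1=O` gives > 200000 nM

Among the compounds with values here, in an ADME assay on MRC5 cells (Homo sapiens) for cytotoxicity, read by MTT assay, with a stated time of 72 h (on this read-out higher numbers stand for weaker inhibition and lower numbers for stronger inhibition), compound 1 gives 80800 nM and is the only compound of the three with a number rather than a limit. For compound 2 this assay reports only a limit, > 200000 nM. For compound 3 the result is likewise a limit, > 200000 nM. Two of the three results therefore sit at the limit of > 200000 nM in this assay, at which 2 of the 3 values shown sit, and compound 1 stands as the single fixed point from which any step must be read.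

Within the data shown here, no pair of measured compounds differs in one place, so no measured step exists. Compound 4 `CSCC[C@H](NC1=CC(=O)C=C(C[C@]2(C)[C@@H](C)CC[C@]3(C)C(C)=CCC[C@@H]23)C1=O)C(=O)O` differs from compound 1 in one place only:

1-carboxy-3-(methylsulfanyl)propyl in place of 2-carboxyethyl on an amine nitrogen

Among the measured compounds shown here, the compound 4 result is the first that will tie a number to this change, since compound 2 and compound 3 carry no number. With the rest of compound 1 kept intact, no movement beyond the scatter is expected, and the step from compound 1 to compound 4 in this assay is estimated as a 1.0-fold lower number from compound 1 to compound 4 (0.00 log units; within the scatter). Compound 4 is accordingly expected near 80000 nM, with a range from 30000 nM to 200000 nM.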

Compound 4, half-maximal inhibitory concentration: > 200000 nM
Compound 4 gave a limit, no number (the forecaster's own chance of this, stated with the estimate: 25%); middle value at least 2.5-fold (0.39 log units) from the limit.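

In this assay, within the data shown here, replacing 2-carboxyethyl with 1-carboxy-3-(methylsulfanyl)propyl on the amine nitrogen, with the shared core kept intact, gives the first step that can be read: an at least 2.4-fold higher number from compound 1 to compound 4 (0.39 log units; beyond the scatter). Compound 4 gives > 200000 nM, which is a limit and not a number. This position is therefore not silent in this read-out, since a change at this amine nitrogen alone moves the result beyond the scatter, but the step has no upper end because the result for compound 4 stops at the limit of the assay: the limit of > 200000 nM in this assay, at which 3 of the 4 values shown sit.

The compounds shown leave open whether the step follows the methylsulfanyl-bearing chain or the 1-carboxy placement, as both change together between these two compounds. A methylsulfanyl-bearing propyl chain with no carboxylic acid on the same amine nitrogen would test the chain on its own, though only a result that is a number and not a limit would give that comparison a size.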